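Aryl substituent swap on the hydantoin-free shared core

The source may hold more compounds than are shown below. What is called first, only, known or untested is meant among the compounds shown, and "the series" means these compounds.

Working notes on the series. The shared core, seen in compound 1 `Cc1ccc(N2C(=O)N/C(=C\c3ccc(O)cc3)C2=O)cc1`, carries a substituted aromatic ring whose single substituent varies. In a functional assay on NCI-H292 cells (Homo sapiens) for antiproliferative activity (a lower number here means a stronger inhibitor, a higher number a weaker inhibitor), compound 1 gives 27900 nM. Compound 2 `COc1ccc(N2C(=O)N/C(=C\c3ccc(O)cc3)C2=O)cc1` carries a methoxy there. In this assay compound 2 reaches only the limit > 200000 nM, a limit of the assay and not a number. Compound 3 `O=C1N/C(=C\c2ccc(O)cc2)C(=O)N1c1ccc(Br)cc1` carries a bromo. In this assay compound 3 gives 69900 nM, the highest of the two numbers shown; the nearest number is that of compound 1, and the step of a 2.5-fold higher number from compound 1 to compound 3 (0.40 log units; beyond the scatter) is modest. The other steps, an at least 7.1-fold higher number from compound 1 to compound 2 (0.85 log units; beyond the scatter) and an at least 2.8-fold lower number from compound 2 to compound 3 (0.45 log units; beyond the scatter), are bounded by the limit (the limit of > 200000 nM in this assay, at which 1 of the 3 values shown sits).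

Compound 4 `O=C(NCC1CCCCC1)c1ccc(N2C(=O)N/C(=C\c3ccc(O)cc3)C2=O)cc1` differs from compound 3 by (cyclohexylmethyl)carbamoyl in place of bromo on an aromatic carbon. Going by the values given here, none of the measured steps places a carbamoyl or a non-aromatic ring at this site; they show only that small substituents there move the number modestly. The new group is much larger than any tried, so the expectation is wide. Compound 4 is estimated at 40000 nM in this assay, with a range from 5000 nM to 200000 nM. The expected step of a 1.7-fold lower number from compound 3 to compound 4 (0.24 log units; within the scatter) is therefore taken as within the scatter in direction, with a real chance of a limit.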

Compound 4, half-maximal inhibitory concentration: > 200000 nM
Compound 4: a limit, no number; the forecaster's own chance of this, stated with the estimate: 20%; middle value at least 5.0-fold (0.69 log units) away from the limit.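

In this assay compound 4 gives > 200000 nM, which is a limit and not a number: the limit of > 200000 nM in this assay, at which 2 of the 4 values shown sit.

Going by these compounds alone, the position does not hold its measurable activity when (cyclohexylmethyl)carbamoyl, the first group with a non-aromatic ring and a hydrogen-bond donor, enters on the aromatic carbon: the notes record an at least 2.8-fold higher number from compound 3 to compound 4 (0.45 log units; beyond the scatter) and an at least 7.1-fold higher number from compound 1 to compound 4 (0.85 log units; beyond the scatter), both lower bounds on the loss set by the limit. The step between compound 2 and compound 4 cannot be read with both at the limit, so these two groups cannot be ordered, and compound 2, with only a methoxy, goes against tying the limit to a large entering group alone.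

Still open, on these data alone, is which part of the new group goes with the loss, the amide link or the cyclohexylmethyl end; a simple methyl amide, a carboxylic acid or an aminomethyl group at this position would begin to separate the two. Also open, as far as these compounds go, is whether any group at this position gives a lower number than the methyl of compound 1, with a chloro or an ethyl as close neighbours to test.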